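Carrying a Triazole Aryl Swap onto a Piperazine Core

The source may hold more compounds than are shown below. What is called first, only, known or untested is meant among the compounds shown, and "the series" means these compounds.

Four close relatives of one scaffold are compared in a functional assay on HT-29 cells (Homo sapiens) for cytotoxicity, read by MTT assay, with a stated time of 72 h; a higher number here means a weaker inhibitor, a lower number a stronger inhibitor. Compound 1 `COc1cc2c(Oc3ccc(NC(=O)c4cn(-c5c(C)cccc5C)nn4)cc3F)ccnc2cc1OCCCN1CCC(C)CC1` gives 2450 nM. Compound 2 `COc1cc2c(Oc3ccc(NC(=O)c4cn(-c5ccc(F)c(F)c5)nn4)cc3F)ccnc2cc1OCCCN1CCC(C)CC1` carries a single difference against compound 1: 3,4-difluorophenyl in place of 2,6-dimethylphenyl on an aromatic nitrogen. The step is a 3.0-fold lower number from compound 1 to compound 2 (0.48 log units; beyond the scatter).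

Compound 3 `COc1cc2c(Oc3ccc(NC(=O)c4cn(-c5c(C)cccc5C)nn4)cc3F)ccnc2cc1OCCCN1CCN(C)CC1` differs from compound 1 only in the core, as follows: 4-methylpiperazin-1-yl in place of 4-methylpiperidin-1-yl on a saturated chain carbon, three bonds along the chain from an oxygen on an aromatic ring. In this assay compound 3 gives 2170 nM, and the step of a 1.1-fold lower number from compound 1 to compound 3 (0.05 log units; within the scatter) means that compound 1 and compound 3 lie within the scatter of each other. Compound 2 stands apart from both: in this assay compound 2 gives 810 nM, a lower number than either of the other two measured compounds.

Compound 4 `COc1cc2c(Oc3ccc(NC(=O)c4cn(-c5ccc(F)c(F)c5)nn4)cc3F)ccnc2cc1OCCCN1CCN(C)CC1` has not yet been measured. Against compound 3 it carries 3,4-difluorophenyl in place of 2,6-dimethylphenyl on an aromatic nitrogen. The description of the place is the same word for word as for the change from compound 1 to compound 2, so this is the same change, now made on the core of compound 3 rather than that of compound 1.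

Among the measured compounds shown here, with only one precedent, the expectation is that the change repeats what it did before. The expected step is a 3.0-fold lower number from compound 3 to compound 4 (0.48 log units; beyond the scatter), because the same change gave a 3.0-fold lower number from compound 1 to compound 2 (0.48 log units; beyond the scatter). Compound 4 is therefore estimated at 720 nM, with a likely range from 350 nM to 1500 nM.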

Compound 4, half-maximal inhibitory concentration: 430 nM
For compound 4 the middle estimate is 1.7-fold (0.22 log units) above the measured one, within the range that was stated.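

In this assay, 3,4-difluorophenyl in place of 2,6-dimethylphenyl on the triazole-bearing aromatic nitrogen again gives a step beyond the scatter on the core of compound 3, a 5.0-fold lower number from compound 3 to compound 4 (0.70 log units; beyond the scatter), and the step agrees with the one seen on the core of compound 1: the same change on two cores in this assay, a 3.0-fold lower number (0.48 log units; beyond the scatter) from compound 1 to compound 2 and a 5.0-fold lower number (0.70 log units; beyond the scatter) from compound 3 to compound 4, 1.7-fold (0.22 log units) apart, within the scatter of two such steps. The other change, 4-methylpiperazin-1-yl in place of 4-methylpiperidin-1-yl, stays within the scatter when made on the 3,4-difluorophenyl compounds, a 1.9-fold lower number from compound 2 to compound 4 (0.28 log units; within the scatter), just as it did on the 2,6-dimethylphenyl compounds: the same change on two cores in this assay, a 1.1-fold lower number (0.05 log units; within the scatter) from compound 1 to compound 3 and a 1.9-fold lower number (0.28 log units; within the scatter) from compound 2 to compound 4, 1.7-fold (0.22 log units) apart, within the scatter of two such steps. Across these four compounds the two changes therefore carry over from one core to the other without any measurable dependence on each other, but the larger step on the core of compound 3 cannot be read as a real gain, and two cores in one cell assay show nothing about how far the pattern extends.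

The compounds shown leave open whether the aryl step holds for other groups on that nitrogen, such as an unsubstituted phenyl or a 4-methoxyphenyl. They also leave open whether the side chain tolerates a morpholine or a dimethylamino group, or a longer chain, as indifferently as it tolerates the two rings compared here.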